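Oxime for benzoyl on the thioether chain: expected paw-edema inhibition

The source may hold more compounds than are shown below. What is called first, only, known or untested is meant among the compounds shown, and "the series" means these compounds.

Measured compounds:
compound 1, `O/N=C(/CSc1nnc(-c2ccccc2)n1-c1ccccc1)c1ccccc1`, 75%
compound 2, `COc1ccc(-c2nnc(SC/C(=N/O)c3ccccc3)n2-c2ccccc2)cc1OC`, 78%
compound 3, `CCn1c(SCC(=O)c2ccccc2)nnc1-c1cc(OC)c(OC)c(OC)c1`, 59%

Among the measured compounds shown here, in a functional assay on the whole organism (strain albino) for inhibition, with Rattus norvegicus as the target, read by paw edema, with a stated time of 5 h, at a dose of 0.28 mmol/kg by the oral route (a lower number here means less inhibition, a higher number more inhibition at the dose given (going by the name of the read-out)), compound 1 gives 75% and compound 2 gives 78%; the step of a number 3 percentage points higher from compound 1 to compound 2 (within the scatter) is the only single-point change measured so far, and it lies within the scatter. Compound 3 gives 59%, the lowest of the three numbers; its gap to compound 1 and to compound 2 is beyond the scatter. Compound 3 differs from those two in more than one place, so none of that gap can be assigned to a single change.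

Compound 4, `CCn1c(SC/C(=N/O)c2ccccc2)nnc1-c1cc(OC)c(OC)c(OC)c1`, has not been measured. The change from compound 3 is a group of 9 heavy atoms (7 carbon, 1 nitrogen, 1 oxygen; one six-membered aromatic ring of carbon only) in place of a group of 8 heavy atoms (7 carbon, 1 oxygen; one six-membered aromatic ring of carbon only), on a saturated chain carbon bound to a sulfur. For the measured compounds named here, no measured step covers this change; the benzoyl compound 3 is the only one of its kind, while compound 1 and compound 2 carry the entering group and stand higher. On that basis a modest rise, a number 8 percentage points higher from compound 3 to compound 4 (within the scatter), is expected, with wide uncertainty. The estimate for compound 4 in this assay is 67%, between 52% and 80%.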

Compound 4, a percentage reported as inhibition, in the whole organism at one dose (the size of the read-out at that dose, not a potency): 74%
For compound 4 the middle estimate is 7 percentage points below the measured one, within the range that was stated.
By their numbers in this assay, from the lowest: compound 3; then compounds 4, 1 and 2 (each within the scatter of the next).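

In this assay, the oxime group in place of benzoyl, on a saturated chain carbon bound to a sulfur, gives a number 15 percentage points higher from compound 3 to compound 4 (beyond the scatter). This is the first single-place change in the series to exceed the scatter, so this position on the thioether chain is shown to respond to the exchange while the rest of the molecule stays constant. The entering group adds one hydrogen-bond donor and a nitrogen, but nothing available here links either feature to the higher number.

From the compounds shown here alone, whether the step carries over to the cores of compound 1 and compound 2 remains open. Also open, going by these compounds, is what a methyl ether of the oxime, an amine or a carboxylic acid would give at the same chain carbon.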